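Dye-Based Conjugates With Dicarboxylic Acid Side Chains in A-375 Cells

The source may report more compounds than this note shows. Statements on the series, on what has been measured and on what is new or still open speak of the compounds shown alone.

Measured compounds in a functional assay on A-375 cells (Homo sapiens) for cytotoxicity, read by CCK-8 assay, with a stated time of 16 h; on this read-out lower numbers stand for stronger inhibition and higher numbers for weaker inhibition:
Compound 1 `COc1ccc(C2=[N+]3C(=Nc4c(-c5ccccc5)c5c(n4[B-]3(F)F)-c3ccc(OCC(=O)N[C@@H](CC(=O)O)C(=O)O)cc3CC5)C(c3ccccc3)=C2I)cc1` gives > 250000 nM, a limit of the assay rather than a number.
Compound 2 `COc1ccc(C2=[N+]3C(=Nc4c(-c5ccccc5)c5c(n4[B-]3(F)F)-c3ccc(OCC(=O)N[C@@H](CCC(=O)O)C(=O)O)cc3CC5)C(c3ccccc3)=C2I)cc1` gives > 250000 nM, likewise a limit.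
Compound 3 `COc1ccc2c(c1)CCc1c(-c3ccccc3)c3n(c1-2)[B-](F)(F)[N+]1=C(c2ccc(OCC(=O)N[C@@H](CC(=O)O)C(=O)O)cc2)C(I)=C(c2ccccc2)C1=N3` gives > 250000 nM, again a limit.

All three measured compounds share an amide-linked dicarboxylic acid tail attached through an ether to a boron-containing dye core. Compound 1 and compound 2 differ by one change, (carboxymethyl in place of carboxy on a saturated chain carbon, two bonds along the chain from an amide-type nitrogen and a carbonyl carbon). Because both values sit at the limit described in the limit of > 250000 nM in this assay, at which 3 of the 3 values shown sit, the step that the two limits leave unreadable from compound 1 to compound 2 cannot be read. Compound 3 carries the same atoms as compound 1 joined differently; the difference between the two cores is not broken down here.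

Compound 4 `COc1ccc2c(c1)CCc1c(-c3ccccc3)c3n(c1-2)[B-](F)(F)[N+]1=C(c2ccc(OCC(=O)N[C@@H](CCC(=O)O)C(=O)O)cc2)C(I)=C(c2ccccc2)C1=N3` has not yet been measured in this assay. It stands to compound 3 as compound 2 stands to compound 1: carboxymethyl in place of carboxy on a saturated chain carbon, two bonds along the chain from an amide-type nitrogen and a carbonyl carbon. For the measured compounds named here, the place of the change is the same in both pairs, so this is the same change, and a step like the unreadable one is expected, a number no higher from compound 3 to compound 4 (the limit leaves the size open), resting on the fact that every value so far, including that of compound 3, sits at the limit named in the limit of > 250000 nM in this assay, at which 3 of the 3 values shown sit. Compound 4 is therefore expected to give about 250000 nM in this assay, most probably again as a limit rather than a number, with a plausible range from 100000 nM to 1000000 nM.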

Compound 4, half-maximal inhibitory concentration: > 250000 nM
Compound 4: no number, only a limit; the forecaster's own chance of this, stated with the estimate: 90%; the middle value sits exactly at the limit.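

In this assay compound 4 gives > 250000 nM, which is a limit of the assay and not a number. No step from compound 3 to compound 4 can be read, because all the values sit at one limit: the limit of > 250000 nM in this assay, at which 4 of the 4 values shown sit.

The compounds shown leave open how far apart compound 1, compound 2, compound 3 and compound 4 truly lie, and whether any of them has a measurable effect in this assay.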